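This account rests on a few compounds, and the source may have more. Where it says the series, first, only, none or still open, it means among the compounds named here.

Measured compounds:
compound 1 `COc1ccc(Nc2ncc(C(F)(F)F)c(N3Cc4cccc(N(C)S(C)(=O)=O)c4C3)n2)cc1C(F)(F)F`: > 30000 nM
compound 2 `CN(c1cccc2c1CN(c1nc(Nc3ccc(C(F)(F)F)cc3)ncc1C(F)(F)F)C2)S(C)(=O)=O`: > 30000 nM

Compound 1 is the starting point. In a functional assay on A549 cells (Homo sapiens) for antiproliferative activity, read by spectrophotometry, with a stated time of 2 days (a lower number here means a stronger inhibitor of growth, a higher number a weaker inhibitor of growth), compound 1 gives > 30000 nM, which is a limit of the assay and not a number. Compound 2 also gives only a limit in this assay, > 30000 nM. The step that the two limits leave unreadable from compound 1 to compound 2 cannot be read in size, since (the limit of > 30000 nM in this assay, at which 2 of the 2 values shown sit). Compound 1 therefore stands at the limit, with no number to place it against.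

The new compound 3 `COc1cc(Nc2ncc(C(F)(F)F)c(N3Cc4cccc(N(C)S(C)(=O)=O)c4C3)n2)cc(C(F)(F)F)c1` differs from compound 1 in one place: 3-methoxy-5-(trifluoromethyl)phenyl in place of 4-methoxy-3-(trifluoromethyl)phenyl on a nitrogen on an aromatic ring. For the measured compounds named here, no measured step bears directly on this rearrangement, and the only step available, from compound 1 to compound 2, is unreadable. With both measured compounds sitting at the same limit, no direction can be expected for compound 3 beyond the scatter, and it is expected most likely to reach only the limit again. The estimate for compound 3 in this assay is 40000 nM, with a range from 12000 nM to 120000 nM. The expected step that the limit leaves unreadable from compound 1 to compound 3 is thus essentially flat.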

Compound 3, concentration for 50% growth inhibition: > 30000 nM
Compound 3: no number, only a limit; the forecaster's own chance of this, stated with the estimate: 80%; the middle value is on the limit's open side.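

For the compounds shown here, compound 3, like compound 1 and compound 2, gives only a limit of the assay in this assay, so no step among the three can be read in size: the limit of > 30000 nM in this assay, at which 3 of the 3 values shown sit. The compounds shown leave open how these three phenyl groups on the nitrogen would rank against one another in growth inhibition.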